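The source may report more compounds than this note shows. Statements on the series, on what has been measured and on what is new or still open speak of the compounds shown alone.

For the measured compounds named here, in a functional assay on DU-145 cells (Homo sapiens) for inhibition, read by trypan blue exclusion, with a stated time of 72 h (a lower number here means a stronger inhibitor, a higher number a weaker inhibitor), compound 1 (`COc1ccc(Nc2ncc3cc(S(=O)(=O)c4ccc(C)cc4)c(=O)n(C)c3n2)cc1`) gives 100000 nM and stands highest of the two numbers so far, while compound 2 (`COc1ccc(Nc2ncc3cc(S(=O)(=O)c4ccc(Cl)cc4)c(=O)n(C)c3n2)cc1`) gives 30000 nM as its value. That pair shows a 3.3-fold lower number from compound 1 to compound 2 (0.52 log units; beyond the scatter) for chloro in place of methyl, a modest change made elsewhere on the molecule. Compound 3 (`Cc1ccc(S(=O)(=O)c2cc3cnc(Nc4cnc5c(c4)CC(=O)N5)nc3n(C)c2=O)cc1`) keeps the methyl and changes the group on a nitrogen on an aromatic ring: a group of 10 heavy atoms (7 carbon, 2 nitrogen, 1 oxygen; one five-membered non-aromatic ring with 1 hetero atom, one six-membered aromatic ring with 1 hetero atom) in place of a group of 8 heavy atoms (7 carbon, 1 oxygen; one six-membered aromatic ring of carbon only), on a nitrogen on an aromatic ring in all. Going by the values given here, no measured step covers this swap, so its size is uncertain. A lower number is expected, with a 5.0-fold lower number from compound 1 to compound 3 (0.70 log units; beyond the scatter) as the estimated step here. For compound 3 the estimated value is 20000 nM within a range of 3000 nM to 100000 nM for now.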

Compound 3, half-maximal inhibitory concentration: 15000 nM
The estimate for compound 3 lay 1.3-fold (0.12 log units) above the measured number, and the stated range covers the measured number.
By their numbers in this assay, from the lowest: compounds 3 and 2 (each within the scatter of the next); then compound 1.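

The earlier pair covered only chloro in place of methyl, whereas this result shows that the group on a nitrogen on an aromatic ring also shifts the number in this assay, with a 6.7-fold lower number from compound 1 to compound 3 (0.82 log units; beyond the scatter). The entering group differs from 4-methoxyphenyl in several features at once, including its ring nitrogen, five-membered ring and hydrogen-bond donor, so this single step cannot separate their contributions. No measurement available here accounts for the shift. On these data alone, what a carboxylic acid or a simple amine would do in this place remains open, as does whether chloro in place of methyl would give a similar step with the new group present.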